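Replacing the 4-chlorophenyl group of compound 3

The compounds below may be only part of what the source reports. "The series", "measured", "known", "first", "only" and "open" are said of these compounds alone.

Measured in a functional assay on U-251 cells (Homo sapiens) for antiproliferative activity, read by MTT assay, with a stated time of 48 h; a higher number here means a weaker inhibitor, a lower number a stronger inhibitor
Compound 1 `COc1ccc(-c2nc3cccc(-c4cc(OC)c(OC)c(OC)c4)c3o2)cc1` gives > 25000 nM
Compound 2 `COc1cc(-c2cccc3nc(-c4ccc(Br)cc4)oc23)cc(OC)c1OC` gives > 25000 nM
Compound 3 `COc1cc(-c2cccc3nc(-c4ccc(Cl)cc4)oc23)cc(OC)c1OC` gives 1600 nM

Within the data shown here, compound 3 holds the only true number here; compound 1 and compound 2 stand at the limit of > 25000 nM in this assay, at which 2 of the 3 values shown sit. Compound 4 `COc1cc(-c2cccc3nc(-c4cccc(N)c4)oc23)cc(OC)c1OC` carries 3-aminophenyl in place of 4-chlorophenyl, (3-aminophenyl in place of 4-chlorophenyl on an aromatic carbon). Two measured steps at this same place lead to compound 3 and both are large, an at least 15-fold lower number from compound 1 to compound 3 (1.19 log units; beyond the scatter) and an at least 15-fold lower number from compound 2 to compound 3 (1.19 log units; beyond the scatter), so losing the chloro is expected to give a higher number. The third, a step that the two limits leave unreadable from compound 1 to compound 2, has no readable size. The expected change is a 3.8-fold higher number from compound 3 to compound 4 (0.57 log units; beyond the scatter). For compound 4 the estimated value is 6000 nM, with an expected range of 1000 nM to 25000 nM.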

Compound 4, half-maximal inhibitory concentration: 2200 nM
Compound 4: middle estimate off by 2.7-fold (0.44 log units), on the high side; the range from low to high includes it.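

In this assay, among these compounds, 3-aminophenyl serves this position as well as 4-chlorophenyl, with a 1.4-fold higher number from compound 3 to compound 4 (0.14 log units; within the scatter), so chloro is not the only group here that gives a measurable value. The new group also stands clearly apart from 4-bromophenyl and 4-methoxyphenyl, with an at least 11-fold lower number from compound 2 to compound 4 (1.05 log units; beyond the scatter) and an at least 11-fold lower number from compound 1 to compound 4 (1.05 log units; beyond the scatter). These two steps rest on a limit, not a true number: the limit of > 25000 nM in this assay, at which 2 of the 4 values shown sit.

The compounds shown leave open how 4-aminophenyl or 3-chlorophenyl would compare, which would separate the effect of the group from that of its place on the ring. On these data alone, a carboxylic acid on this phenyl ring remains equally open.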